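Swapping bromo for methoxy on the amide aryl ring

The compounds below may be only part of what the source reports. "The series", "measured", "known", "first", "only" and "open" are said of these compounds alone.

Three amides sharing one core have been measured in a functional assay on HCT-116 cells (Homo sapiens) for antiproliferative activity, read by MTT assay, with a stated time of 72 h; on this read-out higher numbers stand for weaker inhibition and lower numbers for stronger inhibition: compound 1 `CC(=O)N(C)c1ccc2[nH]c(-c3n[nH]c4ccccc34)cc2n1` gives 14800 nM, compound 2 `CN(C(=O)CCc1ccccc1)c1ccc2[nH]c(-c3n[nH]c4ccccc34)cc2n1` gives 11200 nM, and compound 3 `CN(C(=O)c1ccc(Br)cc1)c1ccc2[nH]c(-c3n[nH]c4ccccc34)cc2n1` gives 6110 nM. Compound 3 has the lowest number of the three, though its gap to compound 2 lies within the scatter, as a 1.8-fold lower number from compound 2 to compound 3 (0.26 log units; within the scatter) shows; only a 2.4-fold lower number from compound 1 to compound 3 (0.38 log units; beyond the scatter) is beyond it. Compound 4 `COc1ccc(C(=O)N(C)c2ccc3[nH]c(-c4n[nH]c5ccccc45)cc3n2)cc1` differs from compound 3 by methoxy in place of bromo on an aromatic carbon. Among the compounds with values here, none of the measured steps touches a substituent on that ring; both concern the group on the carbonyl carbon. No basis exists for expecting a step beyond the scatter. Compound 4 is therefore estimated at 6500 nM, ranging from 2500 nM to 17000 nM. That estimate means a step of a 1.1-fold higher number from compound 3 to compound 4 (0.03 log units; within the scatter), expected to remain within the scatter.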

Compound 4, half-maximal inhibitory concentration: 29500 nM
Estimate against measurement, compound 4: 4.5-fold (0.66 log units) below, and the stated range ends below it.
By their numbers in this assay, from the lowest: compounds 3, 2, 1 and 4 (each within the scatter of the next, the first and the last beyond it).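

The earlier compounds shown here varied only the group on the carbonyl carbon; here, in this assay, a change on the aromatic ring alone, methoxy in place of bromo, gives a 4.8-fold higher number from compound 3 to compound 4 (0.68 log units; beyond the scatter), so the substituent at this position matters. The 4-methoxyphenyl group also compares unfavourably with phenethyl, with a 2.6-fold higher number from compound 2 to compound 4 (0.42 log units; beyond the scatter), while against methyl the result is a 2.0-fold higher number from compound 1 to compound 4 (0.30 log units; within the scatter). Nothing measured here explains the step. Whether the difference tracks bromo or methoxy stays open, as the compounds shown include no chloro, amine or unsubstituted phenyl counterpart at this position.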